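Trimming the amide substituent of an inactive sulfonamide series

A few compounds are considered here, and "the series" means these few. Any claim that something is new, unique, unknown or untested is made for them only; others in the source may bear on it.

Measured compounds:
Compound 1 `CCOC(=O)[C@@H]1CCCN(S(=N)(=O)c2ccc(S(=O)(=O)N(CC)CC)cc2)C1` gives > 10000 nM, which is a limit of the assay.
Compound 2 `CCOC(=O)[C@@H]1CCC[C@@H](S(=O)(=O)c2ccc(S(=O)(=O)N(CC)CC)cc2)C1` gives > 10000 nM, which is a limit of the assay.
Compound 3 `CCN(CC)S(=O)(=O)c1ccc(S(=O)(=O)N2CCC[C@@H](C(=O)NC3CN(C(=O)C4CC4)C3)C2)cc1` gives > 10000 nM, which is a limit of the assay.

In a functional assay on MIA PaCa-2 cells (Homo sapiens) for inhibition, read by MTT assay, with a stated time of 3 days (on this read-out higher numbers stand for weaker inhibition and lower numbers for stronger inhibition), compound 3 stands at the upper limit, as shown by the limit of > 10000 nM in this assay, at which 3 of the 3 values shown sit: no numerical value is known for it or for any measured compound. Compound 4 `CCN(CC)S(=O)(=O)c1ccc(S(=O)(=O)N2CCC[C@@H](C(=O)NC)C2)cc1` differs from compound 3 by methyl in place of 1-(cyclopropylcarbonyl)azetidin-3-yl on an amide-type nitrogen. For the measured compounds named here, no step between measured compounds is available, so the effect of this change is unknown; the expectation is that compound 4 also returns a limit, meaning no step beyond the scatter from compound 3 to compound 4 a step that the limit leaves unreadable from compound 3 to compound 4 is expected. Compound 4 is estimated at 20000 nM, within 5000 nM to 80000 nM.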

Compound 4, half-maximal inhibitory concentration: > 10000 nM
Compound 4 gave a limit, no number; the forecaster's own chance of this, stated with the estimate: 85%; the middle value is on the limit's open side.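

No step can be read from compound 3 to compound 4, because both give only a limit: the limit of > 10000 nM in this assay, at which 4 of the 4 values shown sit.

The compounds shown leave open which change to the amide substituent or the shared core, if any, would give a measurable value.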